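The source may hold more compounds than are shown below. What is called first, only, known or untested is meant among the compounds shown, and "the series" means these compounds.

Working notes on the series. Compound 1 `O=C(/C=C/c1ccccc1)NNC(=O)c1ccccc1O` is the reference point with a number: in a functional assay on ECa-109 cells (Homo sapiens) for cytotoxicity, read by MTT assay, with a stated time of 72 h (on this read-out higher numbers stand for weaker inhibition and lower numbers for stronger inhibition), compound 1 gives 41400 nM. Compound 2 `COCOc1cc(/C=C/C(=O)OCC(=O)Nc2ccc(OC)cc2)ccc1OCc1ccccc1` reaches only a limit of this assay, recorded for compound 2 as > 200000 nM. Compound 3 `COCOc1cc(/C=C/C(=O)OCC(=O)Nc2ccc(Cl)cc2)ccc1OCc1ccccc1` likewise sits at a limit in this assay, recorded for compound 3 as > 200000 nM. Going by the values given here, the one single-point step among the measured compounds, a step that the two limits leave unreadable from compound 2 to compound 3, therefore cannot be read in size or direction, since both ends rest on (the limit of > 200000 nM in this assay, at which 2 of the 3 values shown sit). Compound 4 `COCOc1cc(/C=C/C(=O)OCC(=O)NN2CCOCC2)ccc1OCc1ccccc1` is not yet measured. It differs from compound 3 by morpholin-4-yl in place of 4-chlorophenyl on an amide-type nitrogen. Among the compounds with values here, no measured step bears on this change, and nothing measured shows the shared core of compound 3 giving a number rather than a limit in this assay. The step from compound 3 to compound 4 is expected to be an at least 1.3-fold lower number from compound 3 to compound 4 (0.12 log units; that floor lies within the scatter), read against a limit. Compound 4 is expected to give 150000 nM in this assay, within 40000 nM to 300000 nM, and a further limit is the likelier outcome.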

Compound 4, half-maximal inhibitory concentration: 143000 nM
For compound 4 the middle estimate is 1.0-fold (0.02 log units) above the measured one; the range from low to high includes it.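

In this assay compound 4 gives 143000 nM, the first number rather than a limit for the core shared by compound 2, compound 3 and compound 4. On the amide-type nitrogen, morpholin-4-yl in place of 4-chlorophenyl gives an at least 1.3-fold lower number from compound 3 to compound 4 (0.14 log units; that floor lies within the scatter), and morpholin-4-yl in place of 4-methoxyphenyl gives an at least 1.3-fold lower number from compound 2 to compound 4 (0.14 log units; that floor lies within the scatter). Both steps are floors and not sizes, since each starts from a limit: the limit of > 200000 nM in this assay, at which 2 of the 4 values shown sit.

From the compounds shown here alone, whether the real distance from either aryl compound lies beyond the scatter remains open. Also open, going by these compounds, is whether a number at this position needs the morpholin-4-yl ring and its oxygen, or whether a piperidin-1-yl or dimethylamino group on the same nitrogen would also give a number rather than a limit.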